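The compounds below may be only part of what the source reports. "The series", "measured", "known", "first", "only" and "open" are said of these compounds alone.

In a physicochemical assay for lipophilicity (a lower number here means a more polar compound, a higher number a more lipophilic compound), three compounds built on the same core have been measured. Compound 1 (`COc1cccc2c1c(NS(=O)(=O)c1ccc(Cl)s1)nn2Cc1cccc(CNC(=O)C(C)(C)N)c1`) gives 3.3, compound 2 (`COc1cccc2c1c(NS(=O)(=O)c1ccc(Cl)s1)nn2Cc1cc(CNC(C)=O)ccn1`) gives 2.6, and compound 3 (`COc1cccc2c1c(NS(=O)(=O)c1ccc(Cl)s1)nn2Cc1ccnc(CNC(C)=O)c1`) gives 2.5. Compound 3 therefore stands level with compound 2 within the scatter, while its value lies well under that of compound 1, a gap beyond the scatter.

Compound 4 (`COc1cccc2c1c(NS(=O)(=O)c1ccc(Cl)s1)nn2Cc1cccc(CNC(C)=O)n1`) has not yet been measured. It places 6-(acetamidomethyl)pyridin-2-yl in place of 2-(acetamidomethyl)pyridin-4-yl on a saturated chain carbon bound to an aromatic nitrogen. The two have the same atoms, joined differently.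

For the measured compounds named here, only one measured step is of this kind, an exchange between two arrangements of the same acetamidomethyl pyridine group. That step, a number 0.10 log units lower from compound 2 to compound 3 (within the scatter), stayed within the scatter. No shift beyond the scatter is therefore expected in this assay, and the estimated step is a number 0.20 log units higher from compound 3 to compound 4 (within the scatter). For compound 4 the expected value is 2.7, with an estimated range from 2.3 to 3.1.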

Compound 4, distribution coefficient: 3
For compound 4 the middle estimate is 0.30 log units below the measured one, and the stated range covers the measured number.
By their numbers in this assay, from the lowest: compounds 3 and 2 (each within the scatter of the next); then compounds 4 and 1 (each within the scatter of the next).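

For the compounds shown here, until this result, the only exchange between arrangements of this group on a saturated chain carbon bound to an aromatic nitrogen had stayed small in this assay, with a number 0.10 log units lower from compound 2 to compound 3 (within the scatter), so the arrangement had not been seen to count. The 6-(acetamidomethyl)pyridin-2-yl group now stands apart from both other arrangements, with a number 0.50 log units higher from compound 3 to compound 4 (beyond the scatter) and with a number 0.40 log units higher from compound 2 to compound 4 (beyond the scatter), although the groups exchanged have the same atoms and the same counted features. Nothing available bears on why this arrangement differs.

Still open, on these data alone, is whether a phenyl ring carrying the same acetamidomethyl group would fall with compound 4 or with compound 3. As far as these compounds go, it is equally open whether the shift would persist with an aminomethyl group or a carboxylic acid in place of the acetamidomethyl group.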